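Compound 4: nitrogen in place of oxygen

The compounds below may be only part of what the source reports. "The series", "measured", "known", "first", "only" and "open" are said of these compounds alone.

In an ADME assay on microsomes from liver (Homo sapiens) for metabolic stability (on this read-out lower numbers stand for slow clearance and higher numbers for fast clearance), compound 3 `CC(=O)N[C@@H]1CCC[C@H](C(=O)Nc2cc(-c3cnn4c3COCC4)c(Cl)cn2)C1` gives < 3 mL.min-1.g-1, which is a limit of the assay and not a number. Compound 1 `CC(=O)N[C@@H]1CCC[C@H](C(=O)Nc2cc(-c3cnn4c3CCCC4)c(Cl)cn2)C1` gives 17 mL.min-1.g-1 and compound 2 `CC(=O)N[C@@H]1CCC[C@H](C(=O)Nc2cc(-c3cnc4n3CCCC4)c(Cl)cn2)C1` gives 16 mL.min-1.g-1, and a 1.1-fold lower number from compound 1 to compound 2 (0.03 log units; within the scatter) separates them.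

Compound 4 `CC(=O)N[C@@H]1CCC[C@H](C(=O)Nc2cc(-c3cnn4c3NCCC4)c(Cl)cn2)C1` carries a group of 9 heavy atoms (6 carbon, 3 nitrogen; one five-membered aromatic ring with 2 hetero atoms, one six-membered non-aromatic ring with 2 hetero atoms) in place of a group of 9 heavy atoms (6 carbon, 2 nitrogen, 1 oxygen; one five-membered aromatic ring with 2 hetero atoms, one six-membered non-aromatic ring with 2 hetero atoms), on an aromatic carbon, ortho to a chloro group. The closest measured steps are an at least 5.6-fold lower number from compound 1 to compound 3 (0.75 log units; beyond the scatter) and an at least 5.3-fold lower number from compound 2 to compound 3 (0.72 log units; beyond the scatter). Neither exchanges oxygen for nitrogen, so only part of that gap is expected to return in this assay. The expected change is an at least 2.0-fold higher number from compound 3 to compound 4 (0.30 log units; that floor lies within the scatter), towards a higher number. Compound 4 is estimated at 6 mL.min-1.g-1, with an expected range of 3 mL.min-1.g-1 to 14 mL.min-1.g-1.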

Compound 4, intrinsic clearance in microsomes: 6.2 mL.min-1.g-1
Compound 4: middle estimate off by 1.0-fold (0.01 log units), on the low side; low and high end bracket the measured number.
By their numbers in this assay, from the lowest: compound 4; then compounds 2 and 1 (each within the scatter of the next). At a limit, below all of these: compound 3.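

The exchange of oxygen for nitrogen in the six-membered non-aromatic ring is not neutral in this assay: an at least 2.0-fold higher number from compound 3 to compound 4 (0.31 log units; beyond the scatter). Compound 4 still keeps part of the drop seen with a second hetero atom in that ring: a 2.6-fold lower number from compound 2 to compound 4 (0.41 log units; beyond the scatter), and a 2.7-fold lower number from compound 1 to compound 4 (0.44 log units; beyond the scatter). The first step is only a floor, since compound 3 stands at a limit and not at a number: the limit of < 3 mL.min-1.g-1 in this assay, at which 1 of the 4 values shown sits.

Open, from the compounds shown here alone, is whether a methyl group on the new ring nitrogen would keep clearance this low. Also open, going by these compounds, is how much of the rise belongs to the added hydrogen-bond donor.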